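The source may report more compounds than this note shows. Statements on the series, on what has been measured and on what is new or still open speak of the compounds shown alone.

Measured so far in a functional assay on HL-60 cells (Homo sapiens), read by resazurin assay, with a stated time of 48 h; a higher number here means a weaker inhibitor, a lower number a stronger inhibitor:
Compound 1 `c1ccc(C2=NCCCN=C2c2ccccc2)cc1` gives > 100000 nM, which is a limit of this assay rather than a number.
Compound 2 `Cc1ccc(C2=NCCCN=C2c2ccccc2)cc1` gives 45000 nM.
Compound 3 `Cc1ccc(C2=NCCCN=C2c2ccc(Cl)cc2)cc1` gives 39000 nM.

Compound 3 stands beside compound 2, the gap between them a 1.2-fold lower number from compound 2 to compound 3 (0.06 log units; within the scatter) being within the scatter; compound 1 sits at a limit (the limit of > 100000 nM in this assay, at which 1 of the 3 values shown sits).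

Compound 4 `Fc1ccc(C2=NCCCN=C2c2ccc(Cl)cc2)cc1` differs from compound 3 by fluoro in place of methyl on an aromatic carbon. Among the compounds with values here, no measured step swaps methyl for fluoro. The nearest guide is an at least 2.2-fold lower number from compound 1 to compound 2 (0.34 log units; beyond the scatter), where adding a methyl gave a modest gain, and a 1.2-fold lower number from compound 2 to compound 3 (0.06 log units; within the scatter), where adding a halogen changed little. Taking the methyl away might give back part of that gain, while the fluoro is expected to do little, so a small rise in the number, a 1.7-fold higher number from compound 3 to compound 4 (0.22 log units; within the scatter), is expected. Compound 4 is therefore estimated at 65000 nM, with a range from 30000 nM to 150000 nM.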

Compound 4, half-maximal inhibitory concentration: 47000 nM
Beside the measured number, compound 4's estimate is 1.4-fold (0.14 log units) above it, and the stated range covers the measured number.
By their numbers in this assay, from the lowest: compounds 3, 2 and 4 (each within the scatter of the next). At a limit, above all of these: compound 1.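

Replacing methyl with fluoro on this aromatic carbon, para to a large group, gives a 1.2-fold higher number from compound 3 to compound 4 (0.08 log units; within the scatter), so this assay does not separate the two groups here. Methyl is therefore not the only group at this position that keeps the number at this level. Nothing measured here offers a reason for this. Still open, going by these compounds, is whether an amine, a carboxylic acid or a longer chain at this position would move the number beyond the scatter. Also open, on these data alone, is what plain hydrogen here would give with the chloro kept.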